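Swapping the Amine Ring at the End of the Chain

A few compounds are considered here, and "the series" means these few. Any claim that something is new, unique, unknown or untested is made for them only; others in the source may bear on it.

Measured compounds:
compound 1, `COc1cc2c(Oc3ccc(NC(=O)c4nn(-c5ccccc5C(F)(F)F)c(=O)cc4C)cc3F)ccnc2cc1OCCCN1CCC(C)CC1`: 1120 nM
compound 2, `COc1cc2c(Oc3ccc(NC(=O)c4nn(-c5ccc(Cl)cc5)c(=O)cc4C)cc3F)ccnc2cc1OCCCN1CCCC1`: 1430 nM

Of the compounds shown here, two have been tested in a functional assay on U-87MG ATCC cells (Homo sapiens) for inhibition, read by MTT assay, with a stated time of 72 h; on this read-out higher numbers stand for weaker inhibition and lower numbers for stronger inhibition. Compound 1 `COc1cc2c(Oc3ccc(NC(=O)c4nn(-c5ccccc5C(F)(F)F)c(=O)cc4C)cc3F)ccnc2cc1OCCCN1CCC(C)CC1` gives 1120 nM in this assay. Compound 2 `COc1cc2c(Oc3ccc(NC(=O)c4nn(-c5ccc(Cl)cc5)c(=O)cc4C)cc3F)ccnc2cc1OCCCN1CCCC1` gives 1430 nM in this assay. Of these two numbers, compound 2 has the larger one, but its gap to compound 1 lies within the usual scatter, so the two cannot be separated on this evidence. Compound 1 and compound 2 also differ in more than one place, so no single structural step can be read from them.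

Compound 3 `COc1cc2c(Oc3ccc(NC(=O)c4nn(-c5ccc(Cl)cc5)c(=O)cc4C)cc3F)ccnc2cc1OCCCN1CCC(C)CC1` has not yet been measured. It differs from compound 2 in one place only: 4-methylpiperidin-1-yl in place of pyrrolidin-1-yl on a saturated chain carbon, three bonds along the chain from an oxygen on an aromatic ring. The 4-methylpiperidin-1-yl ring that enters here is already present in compound 1, whose number in this assay sits within the scatter of compound 2, although compound 1 also carries a different aromatic group on the shared core. Within the data shown here, with no measured step to lean on, the expected change from compound 2 to compound 3 is none beyond the scatter, a 1.1-fold lower number from compound 2 to compound 3 (0.04 log units; within the scatter). Compound 3 is therefore expected to give about 1300 nM in this assay, with a range from 500 nM to 3500 nM.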

Compound 3, half-maximal inhibitory concentration: 1350 nM
Compound 3: middle estimate off by 1.0-fold (0.02 log units), on the low side, within the range that was stated.
By their numbers in this assay, from the lowest: compounds 1, 3 and 2 (each within the scatter of the next).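

Among these compounds, compound 2 and compound 3 give the first reading at this position: in this assay, 4-methylpiperidin-1-yl in place of pyrrolidin-1-yl on a saturated chain carbon, three bonds along the chain from an oxygen on an aromatic ring, gives a 1.1-fold lower number from compound 2 to compound 3 (0.03 log units; within the scatter) and so cannot be told apart from no change, even though the ring goes from 5 heavy atoms to 7. Among the compounds shown here, compound 3 also makes compound 1 readable in a single step for the first time, since 4-chlorophenyl in place of 2-(trifluoromethyl)phenyl on an aromatic nitrogen gives a 1.2-fold higher number from compound 1 to compound 3 (0.08 log units; within the scatter) and this second swap likewise cannot be separated from no change. No measurement at hand explains why either swap leaves the number within the scatter.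

From the compounds shown here alone, each swap is seen only once, so it stays open whether pyrrolidin-1-yl and 4-methylpiperidin-1-yl would also match when the group on the aromatic nitrogen is 2-(trifluoromethyl)phenyl. Going by these compounds, it also stays open whether a morpholine ring, an open-chain dimethylamino group or a longer chain between the oxygen and the amine would shift the number beyond the scatter.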